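A few compounds are considered here, and "the series" means these few. Any claim that something is new, unique, unknown or untested is made for them only; others in the source may bear on it.

Compound 1 `COc1ccc(F)cc1CNCCCNc1ccnc2cc(Cc3ccc(F)cc3Cl)ccc12` is the reference point of this set. Going by the values given here, in an ADME assay for permeability, using PAMPA, with a stated time of 30 min, at pH 7.4 (a higher number here means that the compound crosses the layer faster, a lower number that the compound crosses the layer more slowly), compound 1 gives 23 10^-6 cm/s, the lowest of the three numbers measured so far. Compound 2 `COc1ccc(F)cc1CNCCCNc1ccnc2cc(Oc3ccccc3)ccc12` gives 317 10^-6 cm/s and compound 3 `COc1ccc(F)cc1CNCCCNc1ccnc2cc(-c3ccccc3)ccc12` gives 237 10^-6 cm/s. Both measured steps from compound 1, a 14-fold higher number from compound 1 to compound 2 (1.14 log units; beyond the scatter) and a 10-fold higher number from compound 1 to compound 3 (1.01 log units; beyond the scatter), concern the group on the aromatic carbon of the core, while a 1.3-fold lower number from compound 2 to compound 3 (0.13 log units; within the scatter) lies within the scatter. Compound 4 `COc1cccc(CNCCCNc2ccnc3cc(Cc4ccc(F)cc4Cl)ccc23)c1O` differs from compound 1 elsewhere: 2-hydroxy-3-methoxyphenyl in place of 5-fluoro-2-methoxyphenyl on a saturated chain carbon bound to an amine nitrogen. Among the compounds with values here, no measured step touches this position, so nothing in the data bears directly on the change. The step is therefore expected to remain small, a 1.5-fold lower number from compound 1 to compound 4 (0.19 log units; within the scatter), leaning slightly downward. Compound 4 is estimated at 15 10^-6 cm/s, with a range from 5 10^-6 cm/s to 45 10^-6 cm/s.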

Compound 4, apparent permeability: 23 10^-6 cm/s
Compound 4: middle estimate off by 1.5-fold (0.19 log units), on the low side; the measured number falls inside the stated range.
By their numbers in this assay, from the lowest: compounds 1 and 4 (each within the scatter of the next); then compounds 3 and 2 (each within the scatter of the next).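

At this position, on a saturated chain carbon bound to an amine nitrogen, the exchange of 5-fluoro-2-methoxyphenyl for 2-hydroxy-3-methoxyphenyl adds a hydrogen-bond donor and an acceptor, yet in this assay it gives no change at the digits printed from compound 1 to compound 4 (within the scatter). The read-out here therefore stays put through this exchange, whereas the group on the aromatic carbon of the core moves it, with a 14-fold higher number from compound 1 to compound 2 (1.14 log units; beyond the scatter). No available data explain why this exchange leaves the number in place.

Open, as far as these compounds go, is whether this holds with phenoxy or phenyl on the core. Also open, from the compounds shown here alone, is how a carboxylic acid or a piperidine in place of this aromatic ring would read.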